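The compounds below may be only part of what the source reports. "The series", "measured", "known", "first", "only" and "open" are said of these compounds alone.

Measured compounds in this series:

compound 1 `O=C(N/N=C/c1ccc(O)c(O)c1)c1cccnc1Nc1cccc(C(F)(F)F)c1`: 46.9%
compound 2 `COc1ccc(/C=N/NC(=O)c2cccnc2Nc2cccc(C(F)(F)F)c2)cc1`: 42.4%
compound 3 `COc1ccc(/C=N/NC(=O)c2cccnc2Nc2cccc(C(F)(F)F)c2)c(OC)c1`: 44.7%

All three values come from a functional assay on the whole organism (strain Wistar) for inhibition, with Rattus norvegicus as the target, read by paw edema, with a stated time of 2 h, at a dose of 10 mg/kg by the intraperitoneal route; on this read-out lower numbers stand for less inhibition and higher numbers for more inhibition at the one dose given (going by the name of the read-out). Compound 3 lies between the other two on the numbers shown, but the gap to compound 1, a number 2.2 percentage points lower from compound 1 to compound 3 (within the scatter), and the gap from compound 2, a number 2.3 percentage points higher from compound 2 to compound 3 (within the scatter), are both within the scatter, so no order among the three is claimed. The third comparison, a number 4.5 percentage points lower from compound 1 to compound 2 (within the scatter), is likewise within the scatter.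

The next compound, compound 4 `COc1ccc(/C=N/NC(=O)c2cccnc2Nc2cccc(C(F)(F)F)c2)cc1OC`, is not yet measured. The change from compound 3 is 3,4-dimethoxyphenyl in place of 2,4-dimethoxyphenyl on a carbon with a double bond to nitrogen. For the measured compounds named here, no measured step moves a methoxy from one place to another; the nearest case is a number 2.3 percentage points higher from compound 2 to compound 3 (within the scatter), which adds a methoxy and stays within the scatter, and the exchanges of the whole aryl group, a number 4.5 percentage points lower from compound 1 to compound 2 (within the scatter) and a number 2.2 percentage points lower from compound 1 to compound 3 (within the scatter), also stay within the scatter. The expectation for this assay is therefore no step beyond the scatter. Compound 4 is expected to give 44%, with a range of 34% to 54%. The implied step, a number 0.7 percentage points lower from compound 3 to compound 4 (within the scatter), is expected to be within the scatter.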

Compound 4, a percentage reported as inhibition, in the whole organism at one dose (the size of the read-out at that dose, not a potency): 49%
Estimate against measurement, compound 4: 5 percentage points below, within the range that was stated.
By their numbers in this assay, from the lowest: compounds 2, 3, 1 and 4 (each within the scatter of the next).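

In this assay, for the compounds shown here, the exchange of 2,4-dimethoxyphenyl for 3,4-dimethoxyphenyl on the carbon with a double bond to nitrogen is the first step that relocates a methoxy while the atom count stays the same, and a number 4.3 percentage points higher from compound 3 to compound 4 (within the scatter) shows that this relocation stays within the scatter. The second methoxy in its new place also stays within the scatter, at a number 6.6 percentage points higher from compound 2 to compound 4 (within the scatter), as does the exchange of both hydroxyl groups of 3,4-dihydroxyphenyl for methoxy groups, at a number 2.1 percentage points higher from compound 1 to compound 4 (within the scatter); so far, neither the place of a methoxy nor the choice between hydroxyl and methoxy at these places separates the compounds in this assay. No supporting data bear on this result, so the flat picture stands as an observation without an explanation.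

As far as these compounds go, it remains open whether a group of another kind on this phenyl, such as an amine, a carboxylic acid or a longer chain like butoxy, would give a step beyond the scatter. With one dose and one time point, the read-out also leaves open whether compounds that share this range would separate at other doses.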